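Methyl to methoxy on the aryl-pyrazole in two cores

A few compounds are considered here, and "the series" means these few. Any claim that something is new, unique, unknown or untested is made for them only; others in the source may bear on it.

Compound 1 `Cc1ccc(-n2cc(NC(=O)c3cccc(NS(=O)(=O)c4ccc(Cl)cc4)c3)cn2)cc1` and compound 3 `Cc1ccc(-n2cc(NC(=O)c3ccc(NS(=O)(=O)c4ccc(Cl)cc4)cc3)cn2)cc1` share the same atoms joined differently; the difference between the two cores is not broken down here. In a functional assay on HeLa cells (Homo sapiens) for inhibition, read by MTT assay, with a stated time of 48 h (on this read-out lower numbers stand for stronger inhibition and higher numbers for weaker inhibition), compound 1 gives 4570 nM, and compound 3 gives 8010 nM, a gap within the usual scatter.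

Compound 2 `COc1ccc(-n2cc(NC(=O)c3cccc(NS(=O)(=O)c4ccc(Cl)cc4)c3)cn2)cc1` carries the change methoxy in place of methyl on an aromatic carbon on the core of compound 1. In this assay compound 2 gives 19700 nM, so the step of a 4.3-fold higher number from compound 1 to compound 2 (0.63 log units; beyond the scatter) is beyond the scatter, a weakening of inhibition.

Compound 4 `COc1ccc(-n2cc(NC(=O)c3ccc(NS(=O)(=O)c4ccc(Cl)cc4)cc3)cn2)cc1` carries the same change, (methoxy in place of methyl on an aromatic carbon), on the core of compound 3; the place line is identical word for word in both pairs. This change has been measured once among these compounds. Since the two cores sit close in this assay, the step is expected to repeat at about the same size, giving an expected 3.7-fold higher number from compound 3 to compound 4 (0.57 log units; beyond the scatter). On that basis, compound 4 is estimated in this assay to give 30000 nM, with a range from 12000 nM to 80000 nM.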

Compound 4, half-maximal inhibitory concentration: 25200 nM
Beside the measured number, compound 4's estimate is 1.2-fold (0.08 log units) above it; the measured number falls inside the stated range.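

In this assay, going from 4-methylphenyl to 4-methoxyphenyl on the core of compound 3 weakens inhibition, with (a 3.1-fold higher number from compound 3 to compound 4 (0.50 log units; beyond the scatter)) beyond the scatter. For the compounds shown here, this is only two matched pairs on two closely related cores, so it does not show that the change would carry over to a core outside these compounds, and it gives no reason for the loss of inhibition. Within these two cores the change transfers in direction and the two steps do not differ in size: the same change on two cores in this assay, a 4.3-fold higher number (0.63 log units; beyond the scatter) from compound 1 to compound 2 and a 3.1-fold higher number (0.50 log units; beyond the scatter) from compound 3 to compound 4, 1.4-fold (0.14 log units) apart, within the scatter of two such steps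

Still open, on these data alone, is whether the weakening is particular to methoxy or would also appear with another group in the same place on the aromatic ring, such as an amine, a carboxylic acid or a longer chain like ethoxy. The compounds shown also leave open whether the step on either core would hold in any read-out other than this one.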